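The source may hold more compounds than are shown below. What is called first, only, known or untested is meant among the compounds shown, and "the series" means these compounds.

Measured compounds and values

Compound 1 `COc1ccc(C2CC(c3ccco3)=NN2C(C)=O)cc1`: 15500 nM
Compound 2 `CC(=O)N1N=C(c2cccc3ccccc23)CC1c1ccccc1`: 8460 nM
Compound 3 `CC(=O)N1N=C(c2cccc3ccccc23)CC1c1cccc(Cl)c1Cl`: 20100 nM

The numbers come from a functional assay on PC-3 cells (Homo sapiens) for cytotoxicity, read by sulforhodamine B assay, with a stated time of 48 h; a lower number here means a stronger inhibitor, a higher number a weaker inhibitor. Compound 3 gives the highest number of the three: against compound 1 the gap lies within the scatter, while against compound 2 it lies beyond it, as the step of a 2.4-fold higher number from compound 2 to compound 3 (0.38 log units; beyond the scatter) shows for the exchange of phenyl for 2,3-dichlorophenyl on a saturated ring carbon.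

Compound 4 `COc1cc(C2CC(c3cccc4ccccc34)=NN2C(C)=O)ccc1O` is not yet measured. It differs from compound 3 in one place: 4-hydroxy-3-methoxyphenyl in place of 2,3-dichlorophenyl on a saturated ring carbon. Within the data shown here, the one measured step that bears on this position, a 2.4-fold higher number from compound 2 to compound 3 (0.38 log units; beyond the scatter), is modest and ran toward a higher number when the chlorines entered; their removal is therefore expected to take the number back toward that of compound 2, and compound 1, which carries an oxygen-bearing ring at the same carbon, sits close to compound 3. On this basis compound 4 is expected to give 12000 nM in this assay, between 4000 nM and 35000 nM, an estimated step of a 1.7-fold lower number from compound 3 to compound 4 (0.22 log units; within the scatter) that may not clear the scatter.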

Compound 4, half-maximal inhibitory concentration: 2130 nM
The estimate for compound 4 lay 5.6-fold (0.75 log units) above the measured number; measured number outside the range, below it.
By their numbers in this assay, from the lowest: compound 4; then compounds 2, 1 and 3 (each within the scatter of the next, the first and the last beyond it).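

In this assay, 4-hydroxy-3-methoxyphenyl on the saturated ring carbon gives a clear drop in the number, both in place of 2,3-dichlorophenyl (a 9.4-fold lower number from compound 3 to compound 4 (0.97 log units; beyond the scatter)) and in place of phenyl (a 4.0-fold lower number from compound 2 to compound 4 (0.60 log units; beyond the scatter)). Earlier, this position had shown only a rise on going from phenyl to 2,3-dichlorophenyl (a 2.4-fold higher number from compound 2 to compound 3 (0.38 log units; beyond the scatter)); it now shows that substituents on this phenyl ring can move the number in either direction, and that one substituted ring can give a lower number than the unsubstituted phenyl. No measurement at hand accounts for this difference between the two substituted rings.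

The compounds shown leave open whether the drop belongs to the 4-hydroxy group, the 3-methoxy group or the two together. They also leave open how a phenyl ring carrying an amine or a carboxylic acid would read at this carbon.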